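Dechlorination step in a dichloropurine benzyl series

The source may hold more compounds than are shown below. What is called first, only, known or untested is meant among the compounds shown, and "the series" means these compounds.

Among the compounds with values here, compound 2 `ClCc1cccc(Cn2cnc3nc(Cl)nc(Cl)c32)c1` gives 6910 nM in a functional assay on NCI-H522 cells (Homo sapiens) for cytotoxicity, read by sulforhodamine B assay, with a stated time of 48 h (on this read-out higher numbers stand for lower toxicity in this test and lower numbers for higher toxicity in this test), and is the only compound here with a number rather than a limit. Compound 1 `Nc1nc(Cl)c2ncn(Cc3ccccc3CCl)c2n1` reaches only the limit > 100000 nM in this assay, a limit and not a number, as noted at the limit of > 100000 nM in this assay, at which 1 of the 2 values shown sits. Compound 3 `ClCc1cccc(Cn2cnc3ncnc(Cl)c32)c1` is unmeasured and differs from compound 2 by hydrogen in place of chloro on an aromatic carbon. Within the data shown here, no measured pair isolates this change, so the expected step of a 2.2-fold higher number from compound 2 to compound 3 (0.34 log units; beyond the scatter) is small, likely a mild loss of toxicity but possibly within scatter. Compound 3 is therefore estimated at 15000 nM, with a range from 3000 nM to 80000 nM.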

Compound 3, concentration lethal to 50% of the cells: > 100000 nM
Compound 3 gave a limit, no number; the forecaster's own chance of this, stated with the estimate: 20%; middle value at least 6.6-fold (0.82 log units) from the limit.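

Chloro on the aromatic carbon between two ring nitrogen atoms is the first single change that can be read in this series: in this assay hydrogen in its place gives an at least 14-fold higher number from compound 2 to compound 3 (1.16 log units; beyond the scatter). Toxicity in this test therefore depends on what this carbon carries, at least for this pair. Compound 3 holds a limit and not a number, so the step has no upper size: the limit of > 100000 nM in this assay, at which 2 of the 3 values shown sit.

On these data alone, whether a methoxy or a methyl group on this carbon would keep the toxicity of compound 2 remains open.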